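A few compounds are considered here, and "the series" means these few. Any claim that something is new, unique, unknown or untested is made for them only; others in the source may bear on it.

Working notes on the series. Among the measured compounds shown here, compound 1 `COc1cccc(N2CCN(C(=O)C(C)N3C(=O)CCC3=O)CC2)c1` stands highest of the three numbers measured so far: in a functional assay on the whole organism (strain Swiss) with Mus musculus as the target, in the maximal electroshock model, with a stated time of 0.25 h, at a dose of 300 mg/kg by the intraperitoneal route (on this read-out higher numbers stand for a stronger effect at the one dose given and lower numbers for a weaker effect), compound 1 gives 75%. Compound 2 `CCC(C(=O)N1CCN(c2cccc(OC)c2)CC1)N1C(=O)CCC1=O` is nearest, and in this assay compound 2 gives 25%; compound 3 `CCC(C(=O)N1CCOCC1)N1C(=O)CCC1=O` is furthest, and in this assay compound 3 gives 0%. For the measured compounds named here, the one step measured between neighbours, a number 50 percentage points lower from compound 1 to compound 2 (beyond the scatter), concerns the saturated chain carbon and not the aryl group.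

Compound 4 `CC(C(=O)N1CCN(c2ccccc2Cl)CC1)N1C(=O)CCC1=O` differs from compound 1 as follows: 2-chlorophenyl in place of 3-methoxyphenyl on an amine nitrogen in a ring. Going by the values given here, no measured step touches the aryl group on the ring nitrogen, so the pair 1 to 4 has no direct precedent; the only measured step sits elsewhere and cannot be carried over. The expectation is therefore that the number stays in the region of compound 1, with a modest fall allowed for, so that the step from compound 1 to compound 4 is expected to be a number 20 percentage points lower from compound 1 to compound 4 (beyond the scatter). For compound 4 in this assay the estimate is 55%, with a range from 20% to 90%.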

Compound 4, a percentage reported as activity, at one dose (the size of the read-out at that dose, not a potency): 0%
Estimate against measurement, compound 4: 55 percentage points above, outside the stated range (below it).
By their numbers in this assay, from the lowest: compounds 3 and 4 (each within the scatter of the next); then compound 2; then compound 1.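

The aryl group on the amine nitrogen in a ring is a second place where the read-out in this assay responds strongly: 2-chlorophenyl in place of 3-methoxyphenyl gives a number 75 percentage points lower from compound 1 to compound 4 (beyond the scatter). Among the compounds shown here, until now the only measured step lay at the saturated chain carbon, with a number 50 percentage points lower from compound 1 to compound 2 (beyond the scatter), and the earlier compounds showed nothing about the aryl group. No measurement available here bears on the reason for this loss.

The step changes the substituent and its place on the phenyl ring together, and these two changes cannot be told apart from the compounds shown. As far as these compounds go, it also remains open how 3-chlorophenyl, 2-methoxyphenyl or unsubstituted phenyl on the same nitrogen would compare with 3-methoxyphenyl on the core of compound 1.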